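Amide aryl swap on a flavonol series

A few compounds are considered here, and "the series" means these few. Any claim that something is new, unique, unknown or untested is made for them only; others in the source may bear on it.

Two compounds share a flavonol core carrying a fluorophenyl group and an amide-linked aryl ring. Compound 1 `COc1ccccc1C(=O)Nc1cccc(-c2oc3cc(-c4ccc(F)cc4)ccc3c(=O)c2O)c1` gives in a functional assay on HepG2 cells (Homo sapiens) for antiproliferative activity, read by CCK-8 assay, with a stated time of 72 h (on this read-out lower numbers stand for stronger inhibition and higher numbers for weaker inhibition), a value of 14500 nM. Compound 2 `O=C(Nc1cccc(-c2oc3cc(-c4ccc(F)cc4)ccc3c(=O)c2O)c1)c1cccc(F)c1` gives in this assay a value of 15500 nM, which is the higher of the two numbers, though the step of a 1.1-fold higher number from compound 1 to compound 2 (0.03 log units; within the scatter) places it within the scatter of compound 1.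

Compound 3 `O=C(Nc1cccc(-c2oc3cc(-c4ccc(F)cc4)ccc3c(=O)c2O)c1)c1ccc(Br)cc1F` has not been measured. It differs from compound 2 by 4-bromo-2-fluorophenyl in place of 3-fluorophenyl on a carbonyl carbon. For the measured compounds named here, the one measured step that bears on this change is the exchange of aryl groups at the same carbonyl carbon, a 1.1-fold higher number from compound 1 to compound 2 (0.03 log units; within the scatter), which did not move the number beyond the scatter. On that basis the expected step in this assay from compound 2 to compound 3 is a 1.0-fold lower number from compound 2 to compound 3 (0.01 log units; within the scatter), with no clear direction beyond the scatter. Compound 3 is therefore estimated to give 15000 nM in this assay, within a range from 6000 nM to 40000 nM.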

Compound 3, half-maximal inhibitory concentration: > 100000 nM
Compound 3: no number, only a limit; the forecaster's own chance of this, stated with the estimate: 10%; at least 6.6-fold (0.82 log units) between middle value and limit.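

In this assay compound 3 gives only a limit, not a number: the limit of > 100000 nM in this assay, at which 1 of the 3 values shown sits.

This shows that the aryl group on this carbonyl carbon, next to the amide-type nitrogen, cannot be exchanged freely, as the earlier pair alone might have suggested: that exchange gave a 1.1-fold higher number from compound 1 to compound 2 (0.03 log units; within the scatter), whereas 4-bromo-2-fluorophenyl gives an at least 6.4-fold higher number from compound 2 to compound 3 (0.80 log units; beyond the scatter), and likewise an at least 6.8-fold higher number from compound 1 to compound 3 (0.83 log units; beyond the scatter). Both new steps point to weaker inhibition, and both are minimum sizes, so the full size of the loss cannot be read. The result also shows that a single aryl exchange at this place can produce a large change even though the rest of the molecule stays the same.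

The compounds shown leave open whether the bromine or the different placing of the fluorine accounts for the step, since 4-bromo-2-fluorophenyl differs from 3-fluorophenyl in both respects. A 4-bromophenyl or a 2-fluorophenyl group on the same carbonyl carbon would separate the two, and a 4-aminophenyl group would show how this place responds to an amine.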